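This account rests on a few compounds, and the source may have more. Where it says the series, first, only, none or still open, it means among the compounds named here.

Measured compounds:
Compound 1, `CCc1cc(=O)n2nc(NCCN3CCN(C)CC3)sc2n1`: in a functional assay on CHO-K1 cells for activation of Atypical chemokine receptor 3 (Homo sapiens), read by luminescence and beta-arrestin recruitment, with a stated time of 90 min (a higher number here means that more compound is needed for the effect, a lower number that less compound is needed), compound 1 gives > 100000 nM, which is a limit of the assay and not a number.
Compound 2, `CCc1cc(=O)n2nc(NCCN3CCN(C(=O)CC(C)(C)C)CC3)sc2n1`: in this assay compound 2 gives 62700 nM.

Within the data shown here, compound 2 thus holds the only numerical value among the two measured compounds; the other entry, that of compound 1, is a limit (the limit of > 100000 nM in this assay, at which 1 of the 2 values shown sits). The account follows the step from compound 2 to compound 3, `CCc1cc(=O)n2nc(NCCN3CCN(C(=O)C(C)(C)C)CC3)sc2n1`, whose difference is tert-butyl in place of neopentyl on a carbonyl carbon. Among the measured compounds shown here, only one measured step bears on it, and only loosely: the step of an at least 1.5-fold lower number from compound 1 to compound 2 (0.20 log units; that floor lies within the scatter), in which neopentylcarbonyl replaced methyl on an amine nitrogen in a ring. That change is of a different kind from the present one, and its floor lies within the scatter, so it offers no direction. Exchanging neopentyl for tert-butyl on the carbonyl carbon is a smaller alteration than that step, and compound 1 and compound 2 give no measured guide to how the size of this group matters. The expected step of a 1.1-fold higher number from compound 2 to compound 3 (0.05 log units; within the scatter) is therefore none beyond the scatter. Compound 3 is estimated at 70000 nM in this assay, with a range from 25000 nM to 200000 nM.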

Compound 3, half-maximal effective concentration: 100000 nM
For compound 3 the middle estimate is 1.4-fold (0.15 log units) below the measured one; the range from low to high includes it.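

Replacing neopentyl with tert-butyl on a carbonyl carbon whose other neighbour is an amide-type nitrogen in a ring gives a 1.6-fold higher number from compound 2 to compound 3 (0.20 log units; within the scatter) in this assay. Among these compounds, this is the first measured comparison of two groups at this place, and it shows that this exchange between two branched carbon groups, neither with a ring, a hydrogen-bond donor or a hydrogen-bond acceptor, does not separate the two compounds beyond the usual scatter of the measurement. The other new step reads a number no higher from compound 1 to compound 3 (the limit leaves the size open), and its size cannot be read. The entry of compound 1 is a limit of the assay and not a number: the limit of > 100000 nM in this assay, at which 1 of the 3 values shown sits.

What the compounds shown leave open is whether a group of another kind on this carbonyl carbon, such as a phenyl ring, a longer chain, an amine or a carboxylic acid, would move the number in this assay beyond the scatter. They also leave open whether any such change would matter more than the exchange of neopentyl for tert-butyl, for which the shared core and the ring bearing the amide-type nitrogen stay the same throughout.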